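Phenyl in place of a hydroxyethyl chain on the oxime

The source may report more compounds than this note shows. Statements on the series, on what has been measured and on what is new or still open speak of the compounds shown alone.

Among the three measured compounds, compound 1 `Cc1cc2c(F)c(Oc3ncnc(N)c3/C=N/OCCCO)ccc2[nH]1` stands second highest in a functional assay on HeLa cells (Homo sapiens) for antiproliferative activity (a lower number here means a stronger inhibitor, a higher number a weaker inhibitor), where compound 1 gives 362 nM. Its nearest neighbour is compound 2 `COCCO/N=C/c1c(N)ncnc1Oc1ccc2[nH]c(C)cc2c1F`, which gives 308 nM, and the step of a 1.2-fold lower number from compound 1 to compound 2 (0.07 log units; within the scatter) lies within the scatter. Furthest away is compound 3 `CO/N=C/c1c(N)ncnc1Oc1ccc2[nH]ccc2c1`, which gives 1870 nM; compound 3 differs from compound 1 in more than one place, so no single step can be read from that pair.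

Compound 4 `Cc1cc2c(F)c(Oc3ncnc(N)c3/C=N/OCc3ccccc3)ccc2[nH]1` differs from compound 1 in one place: phenyl in place of 2-hydroxyethyl on a saturated chain carbon bound to an oxygen. Among the compounds with values here, only the step from compound 1 to compound 2 bears on this, since it alters the same chain on the oxime oxygen, and it was small. The change to compound 4 is larger in kind: the 2-hydroxyethyl group, with its 1 hydrogen-bond donor and 1 hydrogen-bond acceptor, leaves, and a phenyl with none enters. Within the data shown here, no measured pair tests a phenyl or a benzyloxy group in this position. He therefore expects a modest step of a 1.4-fold higher number from compound 1 to compound 4 (0.14 log units; within the scatter), with the direction uncertain. For compound 4 the estimate is 500 nM, with a range from 150 nM to 1800 nM.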

Compound 4, half-maximal inhibitory concentration: 266 nM
The estimate for compound 4 lay 1.9-fold (0.27 log units) above the measured number; the measured number falls inside the stated range.
By their numbers in this assay, from the lowest: compounds 4, 2 and 1 (each within the scatter of the next); then compound 3.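

In this assay, the oxime chain tolerates a much larger change than the earlier pair had tested: phenyl in place of 2-hydroxyethyl gives a 1.4-fold lower number from compound 1 to compound 4 (0.13 log units; within the scatter) and phenyl in place of methoxymethyl gives a 1.2-fold lower number from compound 2 to compound 4 (0.06 log units; within the scatter) in the same series. Compounds 1 and 2 had only compared two open chains, whereas compound 4 carries a six-membered aromatic ring of carbon only and has 0 hydrogen-bond donors and 0 hydrogen-bond acceptors in the entering group, and neither step leaves the scatter, so across compounds 1, 2 and 4 neither the ring nor the loss of the hydroxyl group separates the numbers. Nothing given here explains why the numbers stay this close.

From the compounds shown here alone, it remains open whether an amine, a carboxylic acid or a longer chain at this place would hold the number as well, or whether a chloro or methoxy group on the phenyl ring would move it beyond the scatter. Going by these compounds, compound 3 differs from compounds 1, 2 and 4 in more than one place, so those pairs cannot be read as single steps, and what the benzyloxy group does on the core of compound 3 stays unknown.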